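Butenolide styryl series: growth inhibition notes

The source may report more compounds than this note shows. Statements on the series, on what has been measured and on what is new or still open speak of the compounds shown alone.

Measured so far:
compound 1 `COc1ccc(/C=C/C2(C)C=CC(=O)O2)c(OC)c1OC` — 87200 nM
compound 2 `COc1c(O)ccc(/C=C/C2(C)C=CC(=O)O2)c1OC` — 40700 nM
compound 3 `CC1(/C=C/c2cccc(O)c2)C=CC(=O)O1` — 118000 nM

All three were run in a functional assay on U-251 cells (Homo sapiens) for inhibition, read by sulforhodamine B assay, with a stated time of 48 h; a lower number here means a stronger inhibitor of growth, a higher number a weaker inhibitor of growth. Going by the values given here, compound 2 gives 40700 nM, and the step of a 2.1-fold higher number from compound 2 to compound 1 (0.33 log units; beyond the scatter) is the one counted change here: methyl in place of hydrogen on an oxygen on an aromatic ring. Compound 3 gives 118000 nM and stands at the high end of the set; its gap to compound 1 lies within the scatter, its gap to compound 2 beyond it. The difference between the core of compound 3 and the core of compound 2 is not broken down here.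

Compound 4 `COc1cccc(/C=C/C2(C)C=CC(=O)O2)c1` has not been measured. It differs from compound 3 by methyl in place of hydrogen on an oxygen on an aromatic ring, the same change as from compound 2 to compound 1, at a place described in the same words. On that single precedent, a step of similar size and direction is expected, a 1.7-fold higher number from compound 3 to compound 4 (0.23 log units; within the scatter), resting on the step of a 2.1-fold higher number from compound 2 to compound 1 (0.33 log units; beyond the scatter) because compound 3 itself already gives 118000 nM. Compound 4 is therefore estimated at 200000 nM, with a range of 90000 nM to 450000 nM in this assay.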

Compound 4, concentration for total growth inhibition: 37600 nM
Compound 4: the middle estimate sits 5.3-fold (0.73 log units) above what was measured; measured number below the stated range.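

In this assay the new step is a 3.1-fold lower number from compound 3 to compound 4 (0.50 log units; beyond the scatter) and it points the other way from the earlier hydroxy to methoxy step, so this change does not carry from one of these cores to the other in either size or direction: the same change on two cores in this assay, a 2.1-fold higher number (0.33 log units; beyond the scatter) from compound 2 to compound 1 and a 3.1-fold lower number (0.50 log units; beyond the scatter) from compound 3 to compound 4, 6.7-fold (0.83 log units) apart, beyond the scatter of two such steps

For this pair of cores, the outcome of the change depends on the core that carries it, and a step read on one core gives no safe estimate for the other. What this does not show is which difference between the two cores lies behind the reversal, and two pairs give no rule for the whole series.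

Left open is how a longer chain on the same oxygen, such as ethyl or propyl in place of methyl, would read on either core. Also open, on these data alone, is whether an amine in place of the hydroxy on the core of compound 3 would follow either step.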